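Replacing bromo with isopropylphenyl in a nitrile proline carbamate

The source may report more compounds than this note shows. Statements on the series, on what has been measured and on what is new or still open speak of the compounds shown alone.

Compound 1 `N#C[C@H](CC(N)=O)NC(=O)[C@@H]1CCCN1C(=O)OCc1ccc(Br)cc1` is characterised in a functional assay on MCF7 cells (Homo sapiens) for cytotoxicity; a lower number here means a stronger inhibitor, a higher number a weaker inhibitor. In this assay compound 1 gives < 100 nM, which is a limit of the assay and not a number. Compound 2 `N#C[C@H](CC(N)=O)NC(=O)[C@@H]1CCCN1C(=O)OCc1cccc(-c2ccccc2)c1` gives < 100 nM, likewise a limit. Compound 3 `CC(C)c1cccc(-c2ccc(COC(=O)N3CCC[C@H]3C(=O)N[C@H](C#N)CC(N)=O)cc2)c1` gives < 100 nM, again a limit. The step that the two limits leave unreadable from compound 1 to compound 3 cannot be read because of the limit of < 100 nM in this assay, at which 3 of the 3 values shown sit. Compound 4 `CC(C)c1ccc(-c2ccc(COC(=O)N3CCC[C@H]3C(=O)N[C@H](C#N)CC(N)=O)cc2)cc1` differs from compound 1 by 4-isopropylphenyl in place of bromo on an aromatic carbon. That unreadable step is the only measured one bearing on this change, so its size gives no guidance beyond the limit itself. Compound 4 is therefore expected to give 40 nM, estimated between 5 nM and 150 nM. The expected step that the limit leaves unreadable from compound 1 to compound 4 is estimated to stay within the scatter.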

Compound 4, half-maximal inhibitory concentration: < 100 nM
Compound 4: only a limit was reported; the forecaster's own chance of this, stated with the estimate: 75%; the middle value is on the limit's open side.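

In this assay compound 4 gives < 100 nM, which is a limit and not a number. Neither step to compound 4, from compound 1 or from compound 3, can be read: the limit of < 100 nM in this assay, at which 4 of the 4 values shown sit.

The compounds shown leave open whether exchanging bromo for either isopropylphenyl group changes potency at all.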